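Notes on the benzylamino series: step from compound 2 to compound 3

A few compounds are considered here, and "the series" means these few. Any claim that something is new, unique, unknown or untested is made for them only; others in the source may bear on it.

Measured so far:
- compound 1 `O=[N+]([O-])c1cccc(CNc2cc(C(F)(F)F)cc3[nH]ncc23)c1` gives 69% in an assay for inhibition of Indoleamine 2,3-dioxygenase 1 (Homo sapiens), with stated times of 10 min and 60 min, tested at 100 uM; on this read-out lower numbers stand for a weaker effect and higher numbers for a stronger effect at the one concentration tested
- compound 2 `OC1CCCC(Nc2cccc(CNc3cc(C(F)(F)F)cc4[nH]ncc34)c2)C1` gives 2% in this assay

Compound 2 stands lowest of the two numbers; its nearest neighbour is compound 1, and the step of a number 67 percentage points lower from compound 1 to compound 2 (beyond the scatter) is large and beyond the scatter, going with (3-hydroxycyclohexyl)amino in place of nitro on an aromatic carbon.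

Compound 3 `CNC(=O)c1cccc(CNc2cc(C(F)(F)F)cc3[nH]ncc23)c1` is not yet measured in this assay. It differs from compound 2 as follows: methylcarbamoyl in place of (3-hydroxycyclohexyl)amino on an aromatic carbon. The group that leaves here is the same one that entered from compound 1 to compound 2, so that step is the only one that bears on the present change. It was large and downward. Within the data shown here, the group that enters now, methylcarbamoyl, is neither nitro nor (3-hydroxycyclohexyl)amino, so no measured pair shows its effect directly; the expectation can only be that removing the (3-hydroxycyclohexyl)amino group gives back part of what was lost, with wide uncertainty.

Compound 3 is therefore expected to give 35% (range 5% to 70%). The expected step is a number 33 percentage points higher from compound 2 to compound 3 (beyond the scatter), upward and beyond the scatter.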

Compound 3, a percentage reported as inhibition, at one concentration (the size of the read-out at that concentration, not a potency): 46%
Estimate against measurement, compound 3: 11 percentage points below; measured number inside the range.
By their numbers in this assay, from the lowest: compound 2; then compound 3; then compound 1.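

Within this assay, the aromatic carbon carrying these groups, meta to a large group, does not lose the read-out with every replacement of nitro: methylcarbamoyl goes with a number 23 percentage points lower from compound 1 to compound 3 (beyond the scatter), a modest step. Set against (3-hydroxycyclohexyl)amino, the same group goes with a number 44 percentage points higher from compound 2 to compound 3 (beyond the scatter), so the collapse at compound 2 belongs to that particular replacement and not to the removal of nitro as such, and the three compounds now form an order at this place, with all three gaps beyond the scatter. Nothing available on these compounds accounts for either step.

On these data alone, with three groups at one place, the smaller, ring-free methylcarbamoyl and the larger, ring-bearing (3-hydroxycyclohexyl)amino differ in several ways at once, so the feature that separates compound 2 from compound 3 remains open. Also open, as far as these compounds go, are how a carboxylic acid, a nitrile or a simple primary amine would read at this place, and whether the order of stronger and weaker effect would hold at other concentrations, given that each number here comes from one concentration only.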